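Swapping the aryl group on compound 1 for a trifluorinated ring

The compounds below may be only part of what the source reports. "The series", "measured", "known", "first", "only" and "open" are said of these compounds alone.

The set contains three measured compounds and one that awaits measurement. Compound 1 `Cc1ccc(-c2cnn3c(NCc4ccccn4)cc(C)nc23)cc1` is the starting point of the step followed here. In a physicochemical assay for solubility, read by HPLC, using the shake flask method, measured as kinetic solubility, with a stated time of 2 h, at pH 7.4 (a lower number here means a less soluble compound, a higher number a more soluble compound), compound 1 returns only a limit, < 5000 nM, so its solubility is known only as a bound, as noted in the limit of < 5000 nM in this assay, at which 1 of the 3 values shown sits. Compound 2 `Cc1cc(NCc2ncccn2)n2nc(C)c(-c3ccccc3)c2n1` gives 37900 nM in this assay. Compound 3 `Cc1cc(NCc2nccn2C)n2nc(C)c(-c3ccccc3)c2n1` gives 26900 nM in this assay. For the measured compounds named here, the one measured step, a 1.4-fold lower number from compound 2 to compound 3 (0.15 log units; within the scatter), concerns the group on the saturated chain carbon bound to the ring nitrogen and does not touch the aryl group that changes here.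

Compound 4 `Cc1cc(NCc2ccccn2)n2ncc(-c3cc(F)c(F)c(F)c3)c2n1` differs from compound 1 in one place: 3,4,5-trifluorophenyl in place of 4-methylphenyl on an aromatic carbon. Going by the values given here, no measured pair in this set varies that aryl group, so the measured step gives no guidance on the size or direction of the change, and the only anchor is the limit of compound 1. Compound 4 is therefore expected to stay near that bound, with the estimated step that the limit leaves unreadable from compound 1 to compound 4, and it may itself be reported only as a limit. The estimate for compound 4 is 3000 nM, with a range from 800 nM to 12000 nM.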

Compound 4, solubility: < 5000 nM
Compound 4: a limit, no number; the forecaster's own chance of this, stated with the estimate: 60%; the middle value does not contradict the limit.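

Compound 1 and compound 4 each return only a limit in this assay, so no step between them can be read, and 3,4,5-trifluorophenyl in place of 4-methylphenyl shows no readable size or direction: the limit of < 5000 nM in this assay, at which 2 of the 4 values shown sit.

The compounds shown leave open where the true values of compound 1 and compound 4 lie and whether this aryl change alters the read-out at all.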